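This account rests on a few compounds, and the source may have more. Where it says the series, first, only, none or still open, it means among the compounds named here.

The shared core here is a chalcone-like chain in which a carbonyl carbon bears a 4-chlorophenyl group and a double-bonded chain carbon carries a sulfur substituent. Compound 1 `O=C(/C(=C\c1c(O)cc(O)cc1O)S(=O)(=O)c1ccccc1Br)c1ccc(Cl)cc1` gives 50000 nM in a functional assay on DU-145 cells (Homo sapiens) for inhibition, read by trypan blue exclusion, with a stated time of 96 h; on this read-out higher numbers stand for weaker inhibition of growth and lower numbers for stronger inhibition of growth. Compound 2 `O=C(/C(=C\c1ccc(Br)cc1)Sc1ccc(Br)cc1)c1ccc(Cl)cc1` gives 1000 nM in this assay. Within the data shown here, compound 3 `O=C(/C(=C\c1c(O)cc(O)cc1O)SCc1ccc(Cl)cc1Cl)c1ccc(Cl)cc1` gives 25000 nM in this assay, the second highest of the three numbers: its nearest neighbour is compound 1, and the only measured single-point step, a 2.0-fold lower number from compound 1 to compound 3 (0.30 log units; within the scatter), lies within the scatter, while compound 2 sits far lower.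

Compound 4 `O=C(/C(=C\c1c(O)cc(O)cc1O)Sc1ccc(Br)cc1)c1ccc(Cl)cc1` has not been measured. It differs from compound 3 in one place: 4-bromophenyl in place of 2,4-dichlorobenzyl on a sulfur. Among the measured compounds shown here, no measured step covers this exact change. Compound 2 carries the same (4-bromophenyl)sulfanyl group but also differs from compound 4 on the other aromatic ring, so its low number cannot be read across directly. For the measured compounds named here, the two compounds that share the 2,4,6-trihydroxyphenyl ring, compound 1 and compound 3, both give high numbers, and the one measured change at the sulfur between them moved little. The expected step of a 1.7-fold lower number from compound 3 to compound 4 (0.22 log units; within the scatter) is therefore modest, with a lean toward a lower number. Compound 4 is estimated at 15000 nM, expected to fall between 3000 nM and 60000 nM.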

Compound 4, concentration for 50% growth inhibition: 50000 nM
The estimate for compound 4 lay 3.3-fold (0.52 log units) below the measured number; measured number inside the range.
By their numbers in this assay, from the lowest: compound 2; then compounds 3, 1 and 4 (each within the scatter of the next).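

At the sulfur, the change from 2,4-dichlorobenzyl to 4-bromophenyl makes little difference in this assay (a 2.0-fold higher number from compound 3 to compound 4 (0.30 log units; within the scatter)), and moving from the (2-bromophenyl)sulfonyl group of compound 1 to the (4-bromophenyl)sulfanyl group of compound 4 leaves the number as it was (no change at the digits printed from compound 1 to compound 4 (within the scatter)). With the 2,4,6-trihydroxyphenyl group held fixed, all three sulfur substituents shown therefore give numbers within the scatter of one another. Among these compounds, the new compound also allows the first single-place comparison for the aromatic group on the double-bonded chain carbon, and here the effect is large: with 2,4,6-trihydroxyphenyl in place of 4-bromophenyl, the result is a 50-fold higher number from compound 2 to compound 4 (1.70 log units; beyond the scatter), so for this pair the low number of compound 2 goes with its 4-bromophenyl group at that position rather than with its sulfur substituent.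

Nothing in the data shown explains why this aromatic group matters so much. Still open is how a phenyl group carrying a single hydroxyl or methoxy group would compare, and whether a sulfur substituent carrying an amine would behave like those shown.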